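Swapping the Ring Substituent: From Bromo to Methoxy

The source may report more compounds than this note shows. Statements on the series, on what has been measured and on what is new or still open speak of the compounds shown alone.

Of the compounds shown here, three have been tested in a functional assay on the whole organism (plasma, strain Wistar) with Rattus norvegicus as the target, with a stated time of 15 days, at a dose of 30 mg/kg by the oral route (on this read-out lower numbers stand for a weaker effect and higher numbers for a stronger effect at the one dose given), and all share one core with a small group varied on an aromatic carbon at its far end. Compound 1 `O=C1NC(=O)/C(=C/c2ccc(OCCSc3nnc(Cc4ccccc4)[nH]3)cc2)S1` gives 28.5% in this assay. Compound 2 `Cc1ccc(-c2nnc(SCCOc3ccc(/C=C4\SC(=O)NC4=O)cc3)[nH]2)cc1` gives 22.6%, and compound 3 `O=C1NC(=O)/C(=C/c2ccc(OCCSc3nnc(-c4ccc(Br)cc4)[nH]3)cc2)S1` gives 19.5%. Compound 3 thus holds the lowest of the three numbers, yet its gap to each of the others lies within the scatter: the step of a number 3.1 percentage points lower from compound 2 to compound 3 (within the scatter) and the step of a number 9 percentage points lower from compound 1 to compound 3 (within the scatter) are both small, as is the step of a number 5.9 percentage points lower from compound 1 to compound 2 (within the scatter).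

Compound 4 `COc1ccc(-c2nnc(SCCOc3ccc(/C=C4\SC(=O)NC4=O)cc3)[nH]2)cc1` has not yet been measured. It differs from compound 3 in one place: methoxy in place of bromo on an aromatic carbon. Going by the values given here, the steps that bear on this change are the three already seen, each of which exchanged the group on that same aromatic carbon and each of which stayed within the scatter. Among the compounds with values here, nothing measured so far suggests that exchanging bromo for methoxy should behave differently, so the step of a number 2.5 percentage points higher from compound 3 to compound 4 (within the scatter) is expected to stay within the scatter as well. Compound 4 is therefore estimated to give about 22% in this assay, with a likely range from 12% to 32%.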

Compound 4, a percentage reported as activity, at one dose (the size of the read-out at that dose, not a potency): 40%
The estimate for compound 4 lay 18 percentage points below the measured number, outside the stated range (above it).
By their numbers in this assay, from the lowest: compounds 3, 2 and 1 (each within the scatter of the next); then compound 4.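

In this assay, the group on this aromatic carbon now clearly matters: exchanging bromo for methoxy gives a number 20.5 percentage points higher from compound 3 to compound 4 (beyond the scatter) whereas the earlier exchanges here all stayed within the scatter. Compound 4 also stands apart from the other two, with methoxy in place of methyl giving a number 17.4 percentage points higher from compound 2 to compound 4 (beyond the scatter) and 4-methoxyphenyl in place of benzyl giving a number 11.5 percentage points higher from compound 1 to compound 4 (beyond the scatter) so that it has the strongest effect of the four at this dose. Counting atoms shows that methoxy brings one hydrogen-bond acceptor and bromo brings none, but that count alone does not connect the change to the higher number, and no supporting measurement is available to explain the rise.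

On these data alone, it remains open whether a hydroxy group, an ethoxy group or a dimethylamino group on the same aromatic carbon would behave like methoxy or would fall in with bromo and methyl. Because this assay reports the size of the effect at a single dose, it also leaves open whether compound 4 would keep its lead at other doses or over other treatment times.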